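Swapping 3-fluorophenyl for 1H-indol-4-yl: what solubility to expect

This account rests on a few compounds, and the source may have more. Where it says the series, first, only, none or still open, it means among the compounds named here.

Of the compounds shown here, three sharing one core have been read in a physicochemical assay for solubility (on this read-out higher numbers stand for higher solubility and lower numbers for lower solubility), so far. Compound 1 (`CNC(=O)c1cc(C(=O)NC2CC2)cn(Cc2ccc(OC)cc2)c1=O`) reads >= 143 ug/mL and this is a limit, not a number. Compound 2 (`CNC(=O)c1cc(C(=O)NC2CC2)cn(Cc2ccc(F)cc2)c1=O`) reads >= 162 ug/mL and this too is a limit. Compound 3 (`CNC(=O)c1cc(C(=O)NC2CC2)cn(Cc2cccc(F)c2)c1=O`) reads >= 133 ug/mL and this is again a limit, so it has no exact place on the scale.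

Compound 4 (`CNC(=O)c1cc(C(=O)NC2CC2)cn(Cc2cccc3[nH]ccc23)c1=O`) is still unmeasured. It carries 1H-indol-4-yl in place of 3-fluorophenyl on a saturated chain carbon bound to an aromatic nitrogen.

Among the compounds with values here, three measured steps bear on this. The closest is a step that the two limits leave unreadable from compound 2 to compound 3 at that same place, and that place also changes in a step that the two limits leave unreadable from compound 1 to compound 3 while a step that the two limits leave unreadable from compound 1 to compound 2 swaps fluoro for methoxy on an aromatic carbon. None of them has a readable size, and none brings in 1H-indol-4-yl, so the guide is thin.

In this assay no step beyond the scatter is expected, with only a slight downward lean, and the estimate is an at least 1.2-fold lower number from compound 3 to compound 4 (0.08 log units; that floor lies within the scatter) for this change. Compound 4 is expected at an estimated 110 ug/mL (range 40 ug/mL to 180 ug/mL) and this reading may again be only a limit.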

Compound 4, solubility: 78 ug/mL
For compound 4 the middle estimate is 1.4-fold (0.15 log units) above the measured one; measured number inside the range.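

In this assay, within the data shown here, compound 4 gives 78 ug/mL, the first exact number in this set, and so the change at this saturated chain carbon bound to an aromatic nitrogen has a step with a readable lower bound: an at least 1.7-fold lower number from compound 3 to compound 4 (0.23 log units; that floor lies within the scatter). Against the two compounds with a substituted phenyl at the 4-position of the ring, the same place gives an at least 1.8-fold lower number from compound 1 to compound 4 (0.26 log units; that floor lies within the scatter) and an at least 2.0-fold lower number from compound 2 to compound 4 (0.31 log units; beyond the scatter), and only this last floor lies beyond the usual scatter of repeat measurements. Compounds 1, 2 and 3 all carry limits, the steps among them cannot be read, and each of the three new steps is therefore a floor, so the real drop on moving to 1H-indol-4-yl could be larger.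

The compounds shown do not separate the effect of the added five-membered ring from that of the hydrogen-bond donor that enters with it. As far as these compounds go, it also stays open how this assay would read with an amine or a carboxylic acid on the aromatic ring at this place.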